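The compounds below may be only part of what the source reports. "The series", "measured", "known", "first", "only" and "open" are said of these compounds alone.

Measured compounds:
- compound 1 `N#Cc1c(N)[n+]([O-])c2ccc(Cl)cc2[n+]1[O-]`, 97.3%
- compound 2 `CNc1c(C#N)[n+]([O-])c2cc(Cl)ccc2[n+]1[O-]`, 96.7%

In a functional assay on Ehrlich cells (Mus musculus) for cytotoxicity, read by trypan blue exclusion, with a stated time of 2 h, tested at 10 ug/mL (a higher number here means a weaker effect of the compound at the concentration tested, a lower number a stronger effect), compound 1 gives 97.3% and compound 2 gives 96.7%. Compound 2 holds the lowest of the two numbers, with compound 1 the nearest, but the two values lie within the scatter of each other, so no order between them can be read. Among the compounds with values here, the only measured step, a number 0.6 percentage points lower from compound 1 to compound 2 (within the scatter), is methyl in place of hydrogen on a nitrogen on an aromatic ring and falls within the scatter.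

Compound 3 `CC(=O)N(C(C)=O)c1c(C#N)[n+]([O-])c2cc(Cl)ccc2[n+]1[O-]` is not yet measured. It differs from compound 2 by diacetylamino in place of methylamino on an aromatic carbon. Within the data shown here, no measured step covers this change; the one step available, methyl in place of hydrogen on a nitrogen, shows no movement beyond the scatter. Both measured values sit near the top of the read-out range. On this basis the expected step in this assay is a number 2.7 percentage points lower from compound 2 to compound 3 (within the scatter), which is small and within the scatter. Compound 3 is therefore estimated at 94%, with a range from 82% to 100%.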

Compound 3, a percentage reported as activity, at one concentration (the size of the read-out at that concentration, not a potency): 83.9%
Estimate against measurement, compound 3: 10.1 percentage points above, within the range that was stated.
By their numbers in this assay, from the lowest: compound 3; then compounds 2 and 1 (each within the scatter of the next).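

At the aromatic carbon next to the ring nitrogen and ortho to a cyano group, the read-out in this assay does respond to the substituent: diacetylamino in place of methylamino gives a number 12.8 percentage points lower from compound 2 to compound 3 (beyond the scatter), and diacetylamino in place of amino gives a number 13.4 percentage points lower from compound 1 to compound 3 (beyond the scatter). Within the data shown here, the smaller change at this carbon gave only a number 0.6 percentage points lower from compound 1 to compound 2 (within the scatter), so diacetylamino is the first group to move the number beyond the scatter, and that movement remains modest. Nothing available bears on what lies behind this shift.

Still open, from the compounds shown here alone, is whether one acetyl group is enough, which acetylamino at the same carbon would test, and whether a longer acyl group such as dipropionylamino would go further. The series also leaves open whether the shift persists at other concentrations or exposure times.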